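This account rests on a few compounds, and the source may have more. Where it says the series, first, only, none or still open, it means among the compounds named here.

Two compounds of this series carry a measured result. Compound 1, `O=C1NCCc2nc(C#Cc3ccccc3)sc21`, has a secondary amide in its core. In an assay on HEK293 cells for negative allosteric modulation of metabotropic glutamate receptor 5 (Homo sapiens), read by FLIPR, with a stated time of 1 h (a higher number here means a weaker inhibitor, a lower number a stronger inhibitor), compound 1 gives > 10000 nM, which is a limit of the assay and not a number. Compound 2, `CCC(=O)N1CCc2nc(C#Cc3ccccc3)sc2C1`, carries a propanoyl group on the ring nitrogen instead, and in this assay compound 2 gives 38 nM. Among the values shown, compound 2 therefore stands as the holder of the only real number, since the other entry is the limit described by the limit of > 10000 nM in this assay, at which 1 of the 2 values shown sits.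

Compound 3, `O=C(C1CCCC1)N1CCc2nc(C#Cc3ccccc3)sc2C1`, has not yet been measured. It differs from compound 2 by cyclopentyl in place of ethyl on a carbonyl carbon. Among the measured compounds shown here, no step between two measured compounds is available to guide this change, so the expectation rests on compound 2 alone. The expected step of a 1.3-fold lower number from compound 2 to compound 3 (0.10 log units; within the scatter) is estimated to lie within the usual scatter of this assay, with no clear direction. On that basis compound 3 is expected to give about 30 nM in this assay, with a plausible range from 8 nM to 110 nM.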

Compound 3, half-maximal inhibitory concentration: > 10000 nM
Compound 3 ended at the assay's limit; the forecaster's own chance of this, stated with the estimate: 5%; at least 330-fold (2.52 log units) between middle value and limit.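

Before this result, no step at this position could be read, and compound 2 stood alone as the only compound with a real number. The position, a carbonyl carbon whose other neighbour is an amide-type nitrogen in a ring, now proves far from indifferent to what it carries: in this assay, cyclopentyl in place of ethyl brings an at least 260-fold higher number from compound 2 to compound 3 (2.42 log units; beyond the scatter), a large step that lies well beyond the scatter. For compound 3 the result is a limit of the assay and not a number, so the step gives only a bound on the size of the change, and the series now stands as follows: the limit of > 10000 nM in this assay, at which 2 of the 3 values shown sit.

The compounds shown cannot tell whether the added carbons or the ring itself goes with this step, and the real value of compound 3 remains unknown. Nor do they say how far the position tolerates anything between ethyl and cyclopentyl, such as a cyclopropyl, an isopropyl or a longer chain, or how a group carrying an amine or an ether oxygen would behave on the same carbonyl carbon.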